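Cytotoxicity Stays at the Assay Limit Across the Set

The compounds below may be only part of what the source reports. "The series", "measured", "known", "first", "only" and "open" are said of these compounds alone.

Compound 3 `CCOC(=O)CCCCCOc1cccc(CN(C(=O)c2ccc(-c3ccncc3)cc2)C(C)C)c1` is one of three amides examined in an ADME assay on Raji cells (Homo sapiens) for cytotoxicity, read by CellTiter-Glo and resazurin assay, with a stated time of 72 h; on this read-out lower numbers stand for an effect already at smaller amounts and higher numbers for an effect only at larger amounts of compound. In this assay compound 3 gives > 26000 nM, which is a limit of the assay and not a number. Compound 1 `CC(=O)Nc1cccc(-c2ccc(C(=O)N(Cc3cccc(OCCCCCC(=O)O)c3)C(C)C)cc2)c1` gives > 26000 nM in this assay, likewise only a limit. Compound 2 `CC(C)N(Cc1cccc(OCCCCCC(=O)O)c1)C(=O)c1ccc(-c2ccncc2)cc1` gives > 26000 nM in this assay, again a limit. All three measured compounds therefore stand at the limit of > 26000 nM in this assay, at which 3 of the 3 values shown sit, and compound 3 shares this position rather than holding a readable value of its own.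

On these data alone, the two steps between measured compounds add nothing that can be sized: a step that the two limits leave unreadable from compound 1 to compound 2 and a step that the two limits leave unreadable from compound 2 to compound 3 both join two limits, so their direction and magnitude remain unknown.

Compound 4 `CCOC(=O)CCCCCOc1cccc(CN(C(=O)c2ccc(-c3ccc4c(c3)OCCO4)cc2)C(C)C)c1` differs from compound 3 by 2,3-dihydro-1,4-benzodioxin-6-yl in place of pyridin-4-yl on an aromatic carbon. For the measured compounds named here, no measured step bears on this exchange, and the steps that do exist are unreadable, so no direction beyond the scatter can be predicted. In line with the three limits already seen, compound 4 is expected to sit near the same ceiling in this assay, with the step of a number no higher from compound 3 to compound 4 (the limit leaves the size open) estimated as essentially flat. The estimate for compound 4 in this assay is 26000 nM, within 9000 nM to 60000 nM.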

Compound 4, half-maximal effective concentration: > 24400 nM
Compound 4 ended at the assay's limit (the forecaster's own chance of this, stated with the estimate: 80%); the middle value lies beyond the limit too.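

In this assay compound 4 gives > 24400 nM, which is a limit of the assay and not a number. For the compounds shown here, compound 3 also stands at a limit, so no step between compound 3 and compound 4 can be read. The compounds shown leave open whether any of them reaches a readable value in this assay, and whether 2,3-dihydro-1,4-benzodioxin-6-yl in place of pyridin-4-yl changes that value at all.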